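This account rests on a few compounds, and the source may have more. Where it says the series, first, only, none or still open, it means among the compounds named here.

Three compounds sharing one core, and differing only in the group on a saturated chain carbon bound to a sulfur, have been measured in a toxicity assay on GES1 cells (Homo sapiens) for inhibition, read by MTT assay, with a stated time of 72 h; on this read-out lower numbers stand for stronger inhibition and higher numbers for weaker inhibition. Compound 1 `Cc1cc(N2CC[C@@H](C)[C@@H](N(C)c3ncnc4[nH]ccc34)C2)n2nc(SCc3ccccc3)nc2n1` gives 67200 nM, and compound 2 `Cc1cc(N2CC[C@@H](C)[C@@H](N(C)c3ncnc4[nH]ccc34)C2)n2nc(SCc3nc4ccccc4[nH]3)nc2n1` gives 40200 nM. That is a 1.7-fold lower number from compound 1 to compound 2 (0.22 log units; within the scatter). Compound 3 `C=CCSc1nc2nc(C)cc(N3CC[C@@H](C)[C@@H](N(C)c4ncnc5[nH]ccc45)C3)n2n1` gives > 100000 nM, which is a limit of the assay and not a number. On the numbers shown, it stands at the limit of > 100000 nM in this assay, at which 1 of the 3 values shown sits.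

Compound 4 `Cc1ccc(CSc2nc3nc(C)cc(N4CC[C@@H](C)[C@@H](N(C)c5ncnc6[nH]ccc56)C4)n3n2)cc1` differs from compound 3 by 4-methylphenyl in place of vinyl on a saturated chain carbon bound to a sulfur, with 4-methylphenyl in place of vinyl on a saturated chain carbon bound to a sulfur. Going by the values given here, two measured steps bear on this change, both read in reverse. The one involving phenyl is an at least 1.4-fold higher number from compound 1 to compound 3 (0.17 log units; that floor lies within the scatter). The one involving 1H-benzimidazol-2-yl is an at least 2.4-fold higher number from compound 2 to compound 3 (0.39 log units; beyond the scatter). Among the compounds with values here, no measured compound shows what the methyl on the ring adds. Compound 1, at 67200 nM, carries phenyl, the closest group to 4-methylphenyl, so a number in its region is expected. A modest fall from the limit of compound 3 is the likely direction. The expected size of the change is an at least 1.8-fold lower number from compound 3 to compound 4 (0.25 log units; that floor lies within the scatter). For compound 4 the estimated value is 55000 nM, with an expected range from 25000 nM to 100000 nM.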

Compound 4, half-maximal inhibitory concentration: 82500 nM
Beside the measured number, compound 4's estimate is 1.5-fold (0.18 log units) below it; measured number inside the range.
By their numbers in this assay, from the lowest: compounds 2, 1 and 4 (each within the scatter of the next, the first and the last beyond it). At a limit, above all of these: compound 3.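

In this assay, a methyl on an aromatic carbon gives a 1.2-fold higher number from compound 1 to compound 4 (0.09 log units; within the scatter), so the added methyl does not separate the two compounds. Going by these compounds alone, at the saturated chain carbon bound to a sulfur, 4-methylphenyl in place of 1H-benzimidazol-2-yl gives a 2.1-fold higher number from compound 2 to compound 4 (0.31 log units; beyond the scatter), the only step between two actual numbers here that passes the scatter, whereas 4-methylphenyl in place of vinyl gives an at least 1.2-fold lower number from compound 3 to compound 4 (0.08 log units; that floor lies within the scatter). Compound 3 remains a limit of the assay and not a number, so the true distance of the vinyl compound from the aromatic groups stays unsettled: the limit of > 100000 nM in this assay, at which 1 of the 4 values shown sits.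

The compounds shown leave open whether a chlorine or a methoxy group in place of the ring methyl would keep the number in the same region. They also leave open whether an amine or a carboxylic acid on the ring, or a longer chain on the sulfur, would shift the number beyond the scatter of the phenyl compound, compound 1.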